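The source may hold more compounds than are shown below. What is called first, only, known or untested is meant among the compounds shown, and "the series" means these compounds.

Three measured compounds share one core: compound 1 `COC(=O)c1coc(/C=C/c2ccc(F)cc2)n1`, compound 2 `COC(=O)c1coc(/C=C/c2ccc(OC)cc2)n1` and compound 3 `COC(=O)c1coc(/C=C/c2ccc(C)cc2)n1`. In an ADME assay on Vero cells (Chlorocebus sabaeus) for cytotoxicity, read by WST assay, tested at 100 ug/mL (a lower number here means a stronger effect, a higher number a weaker effect of the compound at the concentration tested), compound 1 gives 99%, compound 2 gives 96.8% and compound 3 gives 100%. Compound 3 holds the highest of the three numbers, yet a number 1 percentage points higher from compound 1 to compound 3 (within the scatter) and a number 3.2 percentage points higher from compound 2 to compound 3 (within the scatter) both fall within the scatter, as does a number 2.2 percentage points lower from compound 1 to compound 2 (within the scatter). The three swaps on the six-membered aromatic ring of carbon only thus leave this assay essentially unmoved.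

Compound 4 `COC(=O)c1coc(/C=C/c2ccccc2)n1` differs from compound 3 by hydrogen in place of methyl on an aromatic carbon. Going by the values given here, no measured step removes a group to leave hydrogen, so none matches this change directly. The nearest comparisons are the three swaps at the same place, each within the scatter, and nothing in them points to a direction. The expected step is a number 1 percentage points lower from compound 3 to compound 4 (within the scatter), nothing beyond the scatter. Compound 4 is therefore estimated at 99% in this assay, with a range from 92% to 100%. A reported limit rather than a number is not expected.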

Compound 4, a percentage reported as activity, at one concentration (the size of the read-out at that concentration, not a potency): 102%
Compound 4: the middle estimate sits 3 percentage points below what was measured; the measured number lies above the stated range.
By their numbers in this assay, from the lowest: compounds 2, 1, 3 and 4 (each within the scatter of the next).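

Hydrogen on this aromatic carbon, para to a large group, extends the reading in this assay to a ring with no group at this place: a number 2 percentage points higher from compound 3 to compound 4 (within the scatter), a number 5.2 percentage points higher from compound 2 to compound 4 (within the scatter) and a number 3 percentage points higher from compound 1 to compound 4 (within the scatter). Removing methyl, methoxy or fluoro altogether therefore registers no more than swapping one for another, and across these four compounds the choice at this place shows no measurable bearing on this read-out. No supporting evidence on these steps is available.

The compounds shown leave open whether an amine or a carboxylic acid at this place would read the same in this assay. They also leave open what a change elsewhere on the shared core would do, such as an amide in place of the methyl ester.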